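The compounds below may be only part of what the source reports. "The series", "measured", "known", "first", "only" and "open" are said of these compounds alone.

Compound 3 `CC(C)C(c1ccc(-c2ccc3cccc(F)c3c2)[nH]c1=O)C1SC(=O)NC1=O` gives 26.3 10^-6 cm/s in an ADME assay on MDCK cells (Canis lupus familiaris) for permeability, in the apical to basolateral direction; a lower number here means that the compound crosses the layer more slowly, a higher number that the compound crosses the layer faster. That value lies within the scatter of compound 1 `CC(C)C(CC1C(=O)NC(=O)N1C)c1ccc(-c2ccc3cccc(F)c3c2)[nH]c1=O`, which gives 17.6 10^-6 cm/s. Compound 2 `CC(C)[C@@H](c1ccc(-c2ccc3cccc(F)c3c2)[nH]c1=O)[C@@H]1OC(=O)NC1=O` gives 3.15 10^-6 cm/s, well beyond the scatter below compound 3.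

Compound 4 `CC(C)C(/C=C1/C(=O)NC(=O)N1C)c1ccc(-c2ccc3cccc(F)c3c2)[nH]c1=O` differs from compound 3 by a group of 9 heavy atoms (5 carbon, 2 nitrogen, 2 oxygen; one five-membered non-aromatic ring with 2 hetero atoms) in place of a group of 7 heavy atoms (3 carbon, 1 nitrogen, 2 oxygen, 1 sulfur; one five-membered non-aromatic ring with 2 hetero atoms), on a saturated chain carbon bound to an aromatic carbon and a saturated chain carbon. Among the compounds with values here, only one measured step changes the group at this place on the chain: a 1.5-fold higher number from compound 1 to compound 3 (0.17 log units; within the scatter). That exchange stayed within the scatter, so it gives no reason to expect a large shift in this assay here. The value of compound 2, 3.15 10^-6 cm/s, shows that numbers well below compound 3 do occur in this small set, so the lower end is kept wide.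

A modest fall is expected, a 1.6-fold lower number from compound 3 to compound 4 (0.22 log units; within the scatter), and this expected step is not beyond the scatter. The estimated value for compound 4 is 16 10^-6 cm/s, with an expected range of 6 10^-6 cm/s to 36 10^-6 cm/s.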

Compound 4, apparent permeability: 14.1 10^-6 cm/s
Beside the measured number, compound 4's estimate is 1.1-fold (0.05 log units) above it, and the stated range covers the measured number.
By their numbers in this assay, from the lowest: compound 2; then compounds 4, 1 and 3 (each within the scatter of the next).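

In this assay, exchanging the ring at this place on the chain gives a 1.9-fold lower number from compound 3 to compound 4 (0.27 log units; within the scatter) and passing between the two groups of identical atom composition gives a 1.2-fold lower number from compound 1 to compound 4 (0.10 log units; within the scatter) within this small set. Compounds 1, 3 and 4 therefore carry three different groups at this place without any step beyond the scatter, so neither the sulfur-containing ring nor the extra double bond outside aromatic rings in compound 4 separates itself here. No measured evidence on the reason for these numbers is available.

Every group shown at this place is a five-membered non-aromatic ring with 2 hetero atoms, so how an amine, a carboxylic acid or an open alkyl chain there would read stays open. Within the data shown here, also open is what sets compound 2 apart, at 3.15 10^-6 cm/s, since no single-place step connects it to the other compounds.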